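Phenyl for cyclohexyl on the brominated core: working notes

The compounds below may be only part of what the source reports. "The series", "measured", "known", "first", "only" and "open" are said of these compounds alone.

In a functional assay on A2780 cells (Homo sapiens) for antiproliferative activity, read by sulforhodamine B assay, with a stated time of 48 h (a higher number here means a weaker inhibitor of growth, a lower number a stronger inhibitor of growth), compound 1 `Cc1ccc(S(=O)(=O)N2CC[C@@H](Cl)C[C@@H]2C2CCCCC2)cc1` gives 72000 nM. Compound 2 `Cc1ccc(S(=O)(=O)N2CC[C@@H](Cl)C[C@@H]2c2ccccc2)cc1` reaches only the limit of > 100000 nM in this assay. Compound 3 `Cc1ccc(S(=O)(=O)N2CC[C@@H](Br)C[C@@H]2C2CCCCC2)cc1` likewise stops at the limit of > 100000 nM. The change from compound 1 to compound 2 is phenyl in place of cyclohexyl on a saturated ring carbon and produced an at least 1.3-fold higher number from compound 1 to compound 2 (0.14 log units; that floor lies within the scatter). The two cores differ by bromo in place of chloro on a saturated ring carbon, which produced an at least 1.3-fold higher number from compound 1 to compound 3 (0.14 log units; that floor lies within the scatter). Compound 4 `Cc1ccc(S(=O)(=O)N2CC[C@@H](Br)C[C@@H]2c2ccccc2)cc1` arises from compound 3 by phenyl in place of cyclohexyl on a saturated ring carbon, the same kind of change, the place now lying two ring bonds from the ring atom that bears a bromo group rather than a chloro group. Compound 4 is expected to give 150000 nM, within 80000 nM to 400000 nM, since compound 3 already sits at the limit of > 100000 nM in this assay, at which 2 of the 3 values shown sit. The expected step that the limit leaves unreadable from compound 3 to compound 4 is estimated from compound 3 resting at that limit.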

Compound 4, concentration for 50% growth inhibition: > 100000 nM
Compound 4: no number, only a limit; the forecaster's own chance of this, stated with the estimate: 85%; the middle value is on the limit's open side.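

Compound 2, compound 3 and compound 4 all rest at a limit, so neither step into compound 4 can be read: the limit of > 100000 nM in this assay, at which 3 of the 4 values shown sit.

The compounds shown leave open how far each lies past that limit in this assay.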